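This account rests on a few compounds, and the source may have more. Where it says the series, first, only, none or still open, it means among the compounds named here.

Measured compounds in a functional assay on the whole organism (Hindlimb) for inhibition, with Mus musculus as the target, with a stated time of 0.5 h; a higher number here means that more compound is needed for the effect, a lower number that less compound is needed:

compound 1, `CC1(C)CC12NC(=O)N(NC(=O)c1ccccc1)C2=O`: 300 mg/kg
compound 2, `Cc1ccc(C(=O)NN2C(=O)NC3(CC3(C)C)C2=O)cc1`: 100 mg/kg
compound 3, `CC1(C)CC12NC(=O)N(NC(=O)c1ccc(Cl)cc1)C2=O`: 100 mg/kg

Compound 3 stands level with compound 2 at the digits reported, and the two of them share the lowest number of the three. Its one clear separation is from compound 1: the step is a 3.0-fold lower number from compound 1 to compound 3 (0.48 log units; beyond the scatter), where a chloro replaces a hydrogen on an aromatic carbon. The step of no change at the digits printed from compound 2 to compound 3 (within the scatter) shows that exchanging a methyl for a chloro at that carbon made no difference beyond the scatter.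

Compound 4, `CC1(C)CC12NC(=O)N(NC(=O)c1ccc(F)cc1)C2=O`, is not yet measured in this assay. It differs from compound 3 by fluoro in place of chloro on an aromatic carbon. Among the measured compounds shown here, no measured compound carries a fluoro, so the only guidance is indirect: a substituent at this aromatic carbon, whether methyl or chloro, gave a modest gain over hydrogen, and the two substituents were indistinguishable from each other. A fluoro is expected to behave much like them, so the step of a 1.5-fold higher number from compound 3 to compound 4 (0.18 log units; within the scatter) is estimated to stay within the scatter. Compound 4 is therefore expected to give about 150 mg/kg, in the range 75 mg/kg to 300 mg/kg.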

Compound 4, minimum effective dose: 100 mg/kg
The estimate for compound 4 lay 1.5-fold (0.18 log units) above the measured number; the measured number falls inside the stated range.
By their numbers in this assay, from the lowest: compounds 2, 3 and 4 (each within the scatter of the next); then compound 1.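

In this assay, the step to the fluoro analogue reads no change at the digits printed from compound 3 to compound 4 (within the scatter), and the comparison with the methyl analogue reads no change at the digits printed from compound 2 to compound 4 (within the scatter), so fluoro cannot be told apart from either chloro or methyl at this aromatic carbon. Set against the unsubstituted compound, the step is a 3.0-fold lower number from compound 1 to compound 4 (0.48 log units; beyond the scatter), which makes fluoro the third group to separate from hydrogen by the same printed margin. Among these four compounds, the clear divide at this carbon therefore lies between hydrogen and each of the three substituents, with no compound going against it, and not among the substituents themselves.

As far as these compounds go, whether an amine, a carboxylic acid or a longer chain at this carbon would hold the number at this shared level, or move it either way, remains open. Nothing available explains why the three substituents read alike.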